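A Hydroxyphenyl Swap on a Series Without Measurable Potency

This account rests on a few compounds, and the source may have more. Where it says the series, first, only, none or still open, it means among the compounds named here.

Compound 1 `CCCSc1nc(N/N=C(\C)c2ccc(OC)cc2)c2nnn(Cc3ccccc3)c2n1` was run in a functional assay on MCF7 cells (Homo sapiens) for antiproliferative activity, read by MTT assay, with a stated time of 72 h; a lower number here means a stronger inhibitor, a higher number a weaker inhibitor. Compound 1 reached only a limit of that assay, > 64000 nM, so no true number places it on the scale. Compound 2 `CCCSc1nc(N/N=C/c2cc(OC)c(OC)c(OC)c2)c2nnn(Cc3ccccc3)c2n1` likewise gave only a limit in this assay, > 64000 nM. Both readings sit at the limit of > 64000 nM in this assay, at which 2 of the 2 values shown sit. Compound 3 `CCCSc1nc(N/N=C(\C)c2ccccc2O)c2nnn(Cc3ccccc3)c2n1` carries 2-hydroxyphenyl in place of 4-methoxyphenyl on a carbon with a double bond to nitrogen. Within the data shown here, with no measured step between compounds to lean on, the expected step is a step that the limit leaves unreadable from compound 1 to compound 3, nothing beyond the usual scatter. Compound 3 is estimated at 80000 nM, with a range from 20000 nM to 300000 nM.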

Compound 3, half-maximal inhibitory concentration: 11000 nM
Compound 3: the middle estimate sits 7.3-fold (0.86 log units) above what was measured, outside the stated range (below it).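

Among these compounds, replacing 4-methoxyphenyl with 2-hydroxyphenyl on this carbon gives the first true number in this assay, with an at least 5.8-fold lower number from compound 1 to compound 3 (0.76 log units; beyond the scatter). This shows that a change at this one place can bring the series onto the measurable scale. The true size of the step stays unknown because compound 1 gives only a limit: the limit of > 64000 nM in this assay, at which 2 of the 3 values shown sit.

The change swaps the group and also moves its oxygen on the ring, and the compounds shown do not separate these two effects. On these data alone, how a 2-aminophenyl group would read at this carbon also remains open.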